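The source may hold more compounds than are shown below. What is called first, only, known or untested is meant among the compounds shown, and "the series" means these compounds.

Measured so far:
compound 1 `c1ccc(CCCN2CCN(CCN(Cc3ccccc3)c3ccccn3)CC2)cc1` — 6.91
compound 2 `c1ccc(CCCN2CCN(CCN(Cc3ccccc3)c3ccccc3)CC2)cc1` — 5.96

In an assay on HEK293 cells for inhibition of sodium-dependent dopamine transporter (Homo sapiens) (on this read-out lower numbers stand for lower potency and higher numbers for higher potency (the scale is a negative logarithm)), compound 1 gives 6.91, the higher of the two numbers recorded. Compound 2 gives 5.96. Among the measured compounds shown here, the only measured step, a number 0.95 log units lower from compound 1 to compound 2 (beyond the scatter), concerns the group on the amine nitrogen and leaves the rest of the molecule untouched.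

Compound 3 `C(=C/c1ccccc1)\CN1CCN(CCN(Cc2ccccc2)c2ccccn2)CC1` is the next candidate. Relative to compound 1 the change is 2-phenylethenyl in place of phenethyl on a saturated chain carbon bound to an amine nitrogen in a ring. The group keeps its heavy-atom count, its single six-membered aromatic ring of carbon only, and its lack of donors and acceptors; the only addition is one double bond outside aromatic rings. For the measured compounds named here, no measured step touches the saturated chain carbon bound to an amine nitrogen in a ring, so the step from compound 1 to compound 2 does not bear on this change, and there is no basis for expecting a shift beyond the scatter: a number 0.11 log units lower from compound 1 to compound 3 (within the scatter) is the expectation. Compound 3 is therefore estimated at 6.8, in the range 6.2 to 7.4.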

Compound 3, logarithm of the reciprocal of the active concentration, log(1/C): 6.1
For compound 3 the middle estimate is 0.70 log units above the measured one; measured number below the stated range.
By their numbers in this assay, from the lowest: compounds 2 and 3 (each within the scatter of the next); then compound 1.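

In this assay, the saturated chain carbon bound to an amine nitrogen in a ring proves sensitive to a small change: 2-phenylethenyl in place of phenethyl gives a number 0.81 log units lower from compound 1 to compound 3 (beyond the scatter). The heavy-atom count, the aromatic ring and the donor and acceptor counts stay the same, so one double bond outside aromatic rings is enough for a step beyond the scatter. The group on the amine nitrogen is therefore no longer the only place in the series with a demonstrated effect on this read-out, and nothing available accounts for the step.

On these data alone, a 4-phenylbutyl chain or a 3-phenylprop-2-yn-1-yl group at this position remains open. Also open, as far as these compounds go, is whether the same step holds with phenyl in place of pyridin-2-yl on the amine nitrogen.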